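A Piperazine Swap on a Sulfonyl Sulfur

The source may report more compounds than this note shows. Statements on the series, on what has been measured and on what is new or still open speak of the compounds shown alone.

In a physicochemical assay for solubility, in phosphate buffer, with a stated time of 24 h, at pH 7.4, tested at 100 uM (a lower number here means a less soluble compound, a higher number a more soluble compound), compound 1 `CCCn1cc(S(=O)(=O)c2ccc(CNC(=O)N3Cc4ccncc4C3)cc2)cn1` gives 105000 nM and compound 2 `O=C(NCc1ccc(S(=O)(=O)N2CCC[C@H](O)C2)cc1)N1Cc2ccncc2C1` stands higher of the two at 215000 nM on these numbers. Compound 3 `CN1CCN(S(=O)(=O)c2ccc(CNC(=O)N3Cc4ccncc4C3)cc2)CC1` differs from compound 2 by 4-methylpiperazin-1-yl in place of 3-hydroxypiperidin-1-yl on a sulfonyl sulfur. Going by the values given here, the only measured step on that sulfur (a 2.0-fold higher number from compound 1 to compound 2 (0.31 log units; beyond the scatter)) is modest and involves a different pair of groups, so it gives weak guidance. An estimated step (a 1.1-fold lower number from compound 2 to compound 3 (0.03 log units; within the scatter)) stays within the scatter, with no direction expected. For compound 3 the expected value is 200000 nM with 100000 nM to 350000 nM as the estimated range.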

Compound 3, solubility: 160000 nM
For compound 3 the middle estimate is 1.3-fold (0.10 log units) above the measured one; low and high end bracket the measured number.
By their numbers in this assay, from the lowest: compounds 1, 3 and 2 (each within the scatter of the next, the first and the last beyond it).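

In this assay, 4-methylpiperazin-1-yl in place of 3-hydroxypiperidin-1-yl on a sulfonyl sulfur gives a step within the scatter (a 1.3-fold lower number from compound 2 to compound 3 (0.13 log units; within the scatter)), so losing the hydroxyl and its stereocentre and adding a second ring nitrogen does not separate the two compounds. Set against 1-propyl-1H-pyrazol-4-yl, the same group also stays within the scatter (a 1.5-fold higher number from compound 1 to compound 3 (0.18 log units; within the scatter)), so compound 3 cannot be told apart from either compound, although compound 1 and compound 2 are separated beyond the scatter. No measurement given here accounts for these numbers. Going by these compounds, whether a carboxylic acid or a primary amine on this sulfur would give a step beyond the scatter remains open.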